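Para substituent swap on the thiochromenone phenyl series

The source may hold more compounds than are shown below. What is called first, only, known or untested is meant among the compounds shown, and "the series" means these compounds.

Measured so far:
Compound 1 `Fc1ccc2c(=S)cc(-c3ccccc3)oc2c1`: 40%
Compound 2 `Fc1ccc(-c2cc(=S)c3ccc(F)cc3o2)cc1`: "not active" (no number reported)
Compound 3 `COc1ccc(-c2cc(=S)c3ccc(F)cc3o2)cc1`: "not active" (no number reported)

In an in vitro assay on BTI-TN-5B1-4 cells for inhibition of Amine oxidase [flavin-containing] A (Homo sapiens), tested at 100 uM (a higher number here means more inhibition at the concentration tested (going by the name of the read-out), a lower number less inhibition), compound 1 gives 40%. In this assay compound 2 is reported as "not active" (no number reported). In this assay, going by the values given here, compound 3 is likewise reported as "not active" (no number reported), with no number behind it, so compound 3 stands among the entries without a single value and has no numeric step to either neighbour. Two of the three measured compounds therefore give no figure at all.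

Compound 4 `Cc1ccc(-c2cc(=S)c3ccc(F)cc3o2)cc1` is the next entry. The change from compound 3 to compound 4 is methyl in place of methoxy on an aromatic carbon.

Among the compounds with values here, no measured step covers this change. The readings available put the shared core with an unchanged ring at a modest value and both substituted rings at no reported activity. Compound 4 is expected to give a low inhibition in this assay, since compound 3 is reported as "not active" (no number reported). For compound 4 the estimate is 10%, within 0% to 35%.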

Compound 4, a percentage reported as inhibition, at one concentration (the size of the read-out at that concentration, not a potency): 40%
Estimate against measurement, compound 4: 30 percentage points below, and the stated range ends below it.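

In this assay, methyl in place of hydrogen on an aromatic carbon, para to a large group, gives no change at the digits printed from compound 1 to compound 4 (within the scatter), so a group at this position does not by itself go with a "not active" entry. The methoxy of compound 3 and the methyl of compound 4 now separate within this position: compound 3 is entered as "not active" while compound 4 gives 40%, although the step between them cannot be read without a number for compound 3. Nothing at hand bears on the reason for this difference.

As far as these compounds go, how far compound 3 falls short of compound 4 stays open. So does whether a longer chain, such as ethyl, or an amine or a carboxylic acid at this position would read like methyl or like methoxy.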